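Bromo in Place of Chloro on the Aryl Ring

The source may report more compounds than this note shows. Statements on the series, on what has been measured and on what is new or still open speak of the compounds shown alone.

In a functional assay on the whole organism (strain Sprague-Dawley) with Rattus norvegicus as the target, read by paw edema, with a stated time of 3 h, at a dose of 50 mg/kg by the oral route (a lower number here means less inhibition, a higher number more inhibition at the dose given (going by the name of the read-out)), compound 1 `CSc1ncc(-c2ccc(S(C)(=O)=O)cc2)n1-c1ccc(F)cc1` gives 40%, compound 2 `CSc1ncc(-c2ccc(S(C)(=O)=O)cc2)n1-c1ccc(Cl)cc1` gives 59.5%, and compound 3 `CCSc1ncc(-c2ccc(S(C)(=O)=O)cc2)n1-c1ccc(Cl)cc1` gives 53.8%. Compound 3 thus stands second highest of the three; the step of a number 5.7 percentage points lower from compound 2 to compound 3 (within the scatter) is within the scatter, while compound 3 lies beyond the scatter above compound 1. Compound 4 `CCSc1ncc(-c2ccc(S(C)(=O)=O)cc2)n1-c1ccc(Br)cc1` differs from compound 3 by bromo in place of chloro on an aromatic carbon. Within the data shown here, the one measured step that bears on this change is a number 19.5 percentage points higher from compound 1 to compound 2 (beyond the scatter), a modest rise for an earlier halogen exchange at the same place; the step of a number 5.7 percentage points lower from compound 2 to compound 3 (within the scatter) concerns a different part of the shared core. A further rise is possible but not secured, so compound 4 is expected to give 58%, between 43% and 73%. This means an expected step of a number 4.2 percentage points higher from compound 3 to compound 4 (within the scatter).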

Compound 4, a percentage reported as inhibition, in the whole organism at one dose (the size of the read-out at that dose, not a potency): 66%
Compound 4: the middle estimate sits 8 percentage points below what was measured; measured number inside the range.
By their numbers in this assay, from the lowest: compound 1; then compounds 3, 2 and 4 (each within the scatter of the next, the first and the last beyond it).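

In this assay, the change from 4-chlorophenyl to 4-bromophenyl gives a number 12.2 percentage points higher from compound 3 to compound 4 (beyond the scatter) and so shows that this aromatic carbon still responds to the halogen when an ethyl chain sits on the sulfur. Together with a number 19.5 percentage points higher from compound 1 to compound 2 (beyond the scatter), it gives two exchanges at this place, each with a rise beyond the scatter as the halogen goes from fluoro to chloro and from chloro to bromo. Nothing given here explains this rise. As far as these compounds go, it remains open whether iodo, methoxy or an amine at this place would hold the number. From the compounds shown here alone, whether bromo brings a similar step with a methyl group on the sulfur also remains open.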